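The compounds below may be only part of what the source reports. "The series", "measured", "known", "first", "only" and "open" are said of these compounds alone.

Measured in a physicochemical assay for solubility, in phosphate buffer, with a stated time of 2 h, at pH 7.4; a lower number here means a less soluble compound, a higher number a more soluble compound:

- compound 1 `CN(C)c1ccc(Nc2nc(-c3ccccn3)cs2)cc1`: 20000 nM
- compound 2 `COc1ccc(Nc2nc(-c3ccccn3)cs2)cc1OC`: 10000 nM
- compound 3 `Cc1ccc(Nc2nc(-c3ccccn3)cs2)nc1`: 10000 nM

Compound 2 is level with compound 3 at 10000 nM. Compound 1, at 20000 nM, lies within the usual scatter of both, so these three values cannot be ranked.

The next compound to be measured is compound 4 `Clc1ccc(Nc2nc(-c3ccccn3)cs2)nc1`. It has chloro in place of methyl on an aromatic carbon, two atoms from the ring nitrogen and para to a large group: chloro in place of methyl on an aromatic carbon. Within the data shown here, no measured pair shows this swap, or any other single change, so the data offer no direct guide. The expectation rests on the closeness of the measured values, with compound 1 at 20000 nM and compound 3 at 10000 nM, and on the swap replacing one heavy atom with one heavy atom. A small downward step in this assay is expected, probably not beyond the scatter: the estimated step is a 1.4-fold lower number from compound 3 to compound 4 (0.15 log units; within the scatter). For compound 4 the estimated value is 7000 nM, with an expected range from 2500 nM to 15000 nM.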

Compound 4, solubility: < 10000 nM
Compound 4 gave a limit, no number; the forecaster's own chance of this, stated with the estimate: 10%; the middle value does not contradict the limit.
By their numbers in this assay, from the lowest: compounds 2, 3 and 1 (each within the scatter of the next).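

In this assay compound 4 gives < 10000 nM, which is a limit of the assay and not a number. Chloro in place of methyl, on an aromatic carbon two atoms from the ring nitrogen and para to a large group, is the first change in one place among these compounds, and it gives a number no higher from compound 3 to compound 4 (the limit leaves the size open). So this position now has a direction that allows no rise, but no size, and the only bound on the reading is this: the limit of < 10000 nM in this assay, at which 1 of the 4 values shown sits.

As far as these compounds go, the true value of compound 4 stays open, and with it whether this swap changes the read-out at all. An amine or a carboxylic acid on the same aromatic carbon would show how this position responds to groups other than methyl and chloro.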